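The compounds below may be only part of what the source reports. "The series", "measured", "known", "first", "only" and "open" are said of these compounds alone.

Measured so far, in a functional assay on A549 cells (Homo sapiens) for inhibition, read by MTT assay, with a stated time of 24 h; on this read-out higher numbers stand for weaker inhibition of growth and lower numbers for stronger inhibition of growth:

Compound 1, `COc1cccc(C(=O)n2c(-c3cn(C)c4ccccc34)nc3ccccc32)c1`: 10200 nM
Compound 2, `COc1ccc(C(=O)n2c(-c3cn(C)c4ccccc34)nc3ccccc32)cc1`: 10400 nM
Compound 3, `COc1cccc(C(=O)n2c(-c3cn(C)c4ccc(Br)cc34)nc3ccccc32)c1`: 10800 nM

The three measured compounds share one core, and their numbers lie close together. Compound 2 differs from compound 1 by 4-methoxyphenyl in place of 3-methoxyphenyl on a carbonyl carbon; this change gives a 1.0-fold higher number from compound 1 to compound 2 (0.01 log units; within the scatter). Compound 3 differs from compound 1 by bromo in place of hydrogen on an aromatic carbon; that change gives a 1.1-fold higher number from compound 1 to compound 3 (0.02 log units; within the scatter). Compound 4, `COc1ccc(C(=O)n2c(-c3cn(C)c4ccc(Br)cc34)nc3ccccc32)cc1`, is not yet measured. It differs from compound 3 by 4-methoxyphenyl in place of 3-methoxyphenyl on a carbonyl carbon, the same change that carries compound 1 to compound 2, here made on the core of compound 3, which carries the bromo group just described. Because the earlier instance of this change gave a 1.0-fold higher number from compound 1 to compound 2 (0.01 log units; within the scatter), a step of about the same size is expected from compound 3 onward: a 1.0-fold higher number from compound 3 to compound 4 (0.00 log units; within the scatter). This expectation rests on a single measured pair, so it is held loosely. Compound 4 is accordingly estimated at 10900 nM in this assay, with a range from 5500 nM to 22000 nM.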

Compound 4, concentration for 50% growth inhibition: 11300 nM
For compound 4 the middle estimate is 1.0-fold (0.02 log units) below the measured one; the range from low to high includes it.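

In this assay, 4-methoxyphenyl in place of 3-methoxyphenyl on a carbonyl carbon gives a 1.0-fold higher number from compound 3 to compound 4 (0.02 log units; within the scatter) on the bromo-bearing core, and this step agrees with the one on the core of compound 1: the same change on two cores in this assay, a 1.0-fold higher number (0.01 log units; within the scatter) from compound 1 to compound 2 and a 1.0-fold higher number (0.02 log units; within the scatter) from compound 3 to compound 4, 1.0-fold (0.01 log units) apart, within the scatter of two such steps. Bromo in place of hydrogen on an aromatic carbon gives a 1.1-fold higher number from compound 2 to compound 4 (0.04 log units; within the scatter) and likewise agrees with its earlier instance: the same change on two cores in this assay, a 1.1-fold higher number (0.02 log units; within the scatter) from compound 1 to compound 3 and a 1.1-fold higher number (0.04 log units; within the scatter) from compound 2 to compound 4, 1.0-fold (0.01 log units) apart, within the scatter of two such steps. For the compounds shown here, each change thus carries from one core to the other without a detectable difference, but every step here lies within the scatter, so this shows only that neither change moves the number measurably on these two cores, not that a step of real size would carry over in the same way.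

The compounds shown hold only methoxyphenyl groups on the carbonyl and only hydrogen or bromo on the aromatic carbon. From the compounds shown here alone, whether an amine, a carboxylic acid or a longer alkoxy chain at either place would give a step beyond the scatter, and whether such a step would carry between cores, remains open.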